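Fluoro to nitro on the pendant aryl of compound 3

This account rests on a few compounds, and the source may have more. Where it says the series, first, only, none or still open, it means among the compounds named here.

Measured so far:
compound 1 `Cc1ccc(-c2ccc(F)cc2)n1-c1ccc(-c2nc3ccccc3s2)cc1` — 4340 nM
compound 2 `COc1cc(-c2ccc(C)n2-c2ccc(-c3nc4ccccc4s3)cc2)cc(OC)c1OC` — 3450 nM
compound 3 `Cc1ccc(-c2ccc(F)cc2)n1-c1ccc(-c2nc3ccc(F)cc3s2)cc1` — 3030 nM

In a functional assay on MDA-MB-231 cells (Homo sapiens) for cytotoxicity, read by sulforhodamine B assay, with a stated time of 48 h (a lower number here means a stronger inhibitor of growth, a higher number a weaker inhibitor of growth), compound 3 gives the lowest of the three numbers, yet its gaps to compound 2 and to compound 1 both sit within the scatter, so no order among the three can be claimed. For the measured compounds named here, the one single-point step known, a 1.4-fold lower number from compound 1 to compound 3 (0.16 log units; within the scatter), also stays within the scatter. Compound 4 `Cc1ccc(-c2ccc([N+](=O)[O-])cc2)n1-c1ccc(-c2nc3ccc(F)cc3s2)cc1` differs from compound 3 by nitro in place of fluoro on an aromatic carbon, read one bond further out as 4-fluorophenyl to 4-nitrophenyl, on the carbon para to a large group. Going by the values given here, no measured step exchanges these two groups, and the sole step in hand changes nothing beyond the scatter; compound 4 is therefore expected to show a 1.0-fold lower number from compound 3 to compound 4 (0.00 log units; within the scatter), no step beyond the scatter. The estimate for compound 4 in this assay is 3000 nM, between 1200 nM and 7500 nM.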

Compound 4, concentration for 50% growth inhibition: 1670 nM
For compound 4 the middle estimate is 1.8-fold (0.25 log units) above the measured one, within the range that was stated.
By their numbers in this assay, from the lowest: compounds 4, 3, 2 and 1 (each within the scatter of the next, the first and the last beyond it).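

Nitro in place of fluoro on the aromatic carbon para to a large group gives a 1.8-fold lower number from compound 3 to compound 4 (0.26 log units; within the scatter) in this assay. This position therefore accepts nitro, with 3 heavy atoms and 2 hydrogen-bond acceptors, in place of fluoro without a step beyond the scatter. No measurement at hand bears on the reason for this step.

On these data alone, whether an amine or a carboxylic acid on this carbon would give a step beyond the scatter remains open. Also open, as far as these compounds go, is how 4-nitrophenyl reads on the core of compound 1.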